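Restoring the urea: from compound 3 toward compound 4

The source may hold more compounds than are shown below. What is called first, only, known or untested is meant among the compounds shown, and "the series" means these compounds.

Of the compounds shown here, three have been measured in a functional assay on UACC-257 cells (Homo sapiens) for inhibition, read by sulforhodamine B assay, with a stated time of 48 h; on this read-out lower numbers stand for stronger inhibition of growth and higher numbers for weaker inhibition of growth. Compound 1 `O=C(Nc1cccc(-n2cc(-c3ccncc3)c(-c3ccc(Cl)c(O)c3)n2)c1)Nc1cccc(C(F)(F)F)c1` gives 4340 nM, and compound 2 `COc1cc(-c2nn(-c3cccc(NC(=O)Nc4cc(C(F)(F)F)cc(C(F)(F)F)c4)c3)cc2-c2ccncc2)ccc1Cl` gives 916 nM. Compound 3 `COc1cc(-c2nn(-c3cccc(NC(=O)c4cccc(C(F)(F)F)c4)c3)cc2-c2ccncc2)ccc1Cl` stands at the weak end of this group: in this assay compound 3 gives 27900 nM, the highest of the three numbers, well beyond the scatter from both compound 1 and compound 2.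

Compound 4 `COc1cc(-c2nn(-c3cccc(NC(=O)Nc4ccc(Cl)c(Cl)c4)c3)cc2-c2ccncc2)ccc1Cl` has not yet been measured. It differs from compound 3 in one place: (3,4-dichlorophenyl)amino in place of 3-(trifluoromethyl)phenyl on a carbonyl carbon. In plain terms, the carbonyl in compound 3 sits between one aromatic ring and one amide nitrogen, while in compound 4 it is flanked by two nitrogens, as it is in compound 1 and compound 2.

Both measured compounds built on that two-nitrogen arrangement gave far lower numbers than compound 3, so the change is expected to bring a sizeable drop, in the direction of stronger growth inhibition, estimated as a 19-fold lower number from compound 3 to compound 4 (1.27 log units; beyond the scatter). Compound 4 is therefore expected to give about 1500 nM in this assay, with a likely range from 500 nM to 5000 nM.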

Compound 4, concentration for 50% growth inhibition: 1040 nM
For compound 4 the middle estimate is 1.4-fold (0.16 log units) above the measured one; the range from low to high includes it.
By their numbers in this assay, from the lowest: compounds 2 and 4 (each within the scatter of the next); then compound 1; then compound 3.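

In this assay, exchanging the aromatic group on the carbonyl carbon gives a 27-fold lower number from compound 3 to compound 4 (1.43 log units; beyond the scatter). This is the only step among these compounds that differs in one place, and it shows that this place has a large effect on the read-out. The step combines two changes, as a nitrogen carrying a hydrogen-bond donor enters and the trifluoromethyl group gives way to two chlorines, and nothing available here explains its size.

The compounds shown leave open how much of the step belongs to the added nitrogen and how much to the ring substituents, which a urea otherwise like compound 4 but carrying a 3-(trifluoromethyl)phenyl ring could separate. As far as these compounds go, how a sulfonamide or a thiourea would behave at this place also remains open.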